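The source may report more compounds than this note shows. Statements on the series, on what has been measured and on what is new or still open speak of the compounds shown alone.

Measured so far:
compound 1 `COC(=O)C1=C(CN2CCOCC2=O)NC(c2nccs2)=NC1(C)c1ccc(F)cc1`: 80 mL/min/kg
compound 2 `COC(=O)C1=C(CN2CCC(O)CC2)NC(c2nccs2)=NC1(C)c1ccc(F)cc1`: 81 mL/min/kg
compound 3 `COC(=O)C1=C(CN2CCCS2(=O)=O)NC(c2nccs2)=NC1(C)c1ccc(F)cc1`: 79 mL/min/kg

All three values come from an ADME assay on microsomes from liver (Mus musculus) for metabolic stability, read by LC-MS, using NADPH, with stated times of 10 min and 30 min, tested at 1 uM; on this read-out lower numbers stand for slow clearance and higher numbers for fast clearance. There, compound 3 at 79 mL/min/kg sits level with compound 1 and compound 2, and all three lie within the scatter of one another.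

Next in view is compound 4 `COC(=O)C1=C(CN2CC(OC)C2)NC(c2nccs2)=NC1(C)c1ccc(F)cc1`, which carries 3-methoxyazetidin-1-yl. The change from compound 3 is a group of 6 heavy atoms (4 carbon, 1 nitrogen, 1 oxygen; one four-membered non-aromatic ring with 1 hetero atom) in place of a group of 7 heavy atoms (3 carbon, 1 nitrogen, 2 oxygen, 1 sulfur; one five-membered non-aromatic ring with 2 hetero atoms), on a saturated chain carbon bound to a double-bonded ring carbon.

Three measured steps at this same place bear on the change: a 1.0-fold higher number from compound 1 to compound 2 (0.01 log units; within the scatter), a 1.0-fold lower number from compound 1 to compound 3 (0.01 log units; within the scatter) and a 1.0-fold lower number from compound 2 to compound 3 (0.01 log units; within the scatter). Each lies within the scatter, although the groups exchanged differ in ring size and in hetero atoms. These steps give no sign that a change at this place moves the number in this assay. Among the measured compounds shown here, none of the measured compounds carries a four-membered ring, however, so the entering ring itself is untested and the range is kept wide.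

The expected step is a 1.0-fold lower number from compound 3 to compound 4 (0.01 log units; within the scatter), with no change beyond the scatter anticipated in either direction. In this assay the estimate for compound 4 is 78 mL/min/kg, with an expected range of 50 mL/min/kg to 100 mL/min/kg.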

Compound 4, clearance: 88 mL/min/kg
Estimate against measurement, compound 4: 1.1-fold (0.05 log units) below; the measured number falls inside the stated range.
By their numbers in this assay, from the lowest: compounds 3, 1, 2 and 4 (each within the scatter of the next).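

Working notes on the series: in this assay the four-membered ring of 3-methoxyazetidin-1-yl, the one ring type at this place that had no reading before, also gives a number within the scatter of all three earlier compounds (a 1.1-fold higher number from compound 3 to compound 4 (0.05 log units; within the scatter); a 1.1-fold higher number from compound 2 to compound 4 (0.04 log units; within the scatter); a 1.1-fold higher number from compound 1 to compound 4 (0.04 log units; within the scatter)). Four-, five- and six-membered non-aromatic rings on the saturated chain carbon bound to a double-bonded ring carbon therefore cannot be told apart across compound 1, compound 2, compound 3 and compound 4, and none of these four goes against that reading. No measurement on hand accounts for this flat response.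

Still open, on these data alone, is whether any group at this place moves the number at all, since all four compounds carry a non-aromatic ring here and a carboxylic acid, an open-chain amine or a longer chain could behave differently. Also open, as far as these compounds go, is whether a change elsewhere on the shared core would move the number in this assay when this place alone has not.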